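A 4-Methoxyphenyl Group Replaces 2-Chlorophenyl

A few compounds are considered here, and "the series" means these few. Any claim that something is new, unique, unknown or untested is made for them only; others in the source may bear on it.

In a functional assay on PC-3 cells (Homo sapiens) for antiproliferative activity, read by MTT assay, with a stated time of 48 h (a lower number here means a stronger inhibitor, a higher number a weaker inhibitor), compound 1 (`Cc1ccc(S(=O)(=O)NC(=O)[C@H](CC(C)C)NC2=NC(=O)/C(=C/c3cccc(Cl)c3)S2)cc1`) gives 16.8 ug/mL, compound 2 (`Cc1ccc(S(=O)(=O)NC(=O)[C@@H](NC2=NC(=O)/C(=C/c3ccccc3Cl)S2)C(C)C)cc1`) gives 11.9 ug/mL and compound 3 (`Cc1ccc(S(=O)(=O)NC(=O)[C@H](CC(C)C)NC2=NC(=O)/C(=C/c3ccccc3Cl)S2)cc1`) gives 15.6 ug/mL. Compound 2 therefore stands level with the other two, all within the scatter. Compound 4 (`COc1ccc(/C=C2\SC(N[C@H](C(=O)NS(=O)(=O)c3ccc(C)cc3)C(C)C)=NC2=O)cc1`) carries 4-methoxyphenyl in place of 2-chlorophenyl on a double-bonded chain carbon bound to a double-bonded ring carbon. Going by the values given here, at this place, the one measured change is a 1.1-fold lower number from compound 1 to compound 3 (0.03 log units; within the scatter). The change of chain is a 1.3-fold higher number from compound 2 to compound 3 (0.12 log units; within the scatter). Among the compounds with values here, both lie within the scatter, but no measured compound carries a methoxy group, so the evidence is thin. The expected step is a 1.1-fold higher number from compound 2 to compound 4 (0.04 log units; within the scatter), and none beyond the scatter is expected. For compound 4 the estimated value is 13 ug/mL, with an expected range of 7 ug/mL to 25 ug/mL.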

Compound 4, half-maximal inhibitory concentration: 20.3 ug/mL
Compound 4: middle estimate off by 1.6-fold (0.19 log units), on the low side; the range from low to high includes it.
By their numbers in this assay, from the lowest: compounds 2, 3, 1 and 4 (each within the scatter of the next).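

In this assay, going by these compounds alone, 4-methoxyphenyl in place of 2-chlorophenyl gives a 1.7-fold higher number from compound 2 to compound 4 (0.23 log units; within the scatter), so this place, until now seen only with chlorophenyl groups, also takes a group bearing oxygen without a step beyond the scatter. Nothing at hand gives a reason for this result. Going by these compounds, whether the same holds with 4-methoxyphenyl on the isobutyl chain of compound 3 stays open. So does the outcome with an amine or a carboxylic acid on the phenyl ring at this place.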